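A few compounds are considered here, and "the series" means these few. Any claim that something is new, unique, unknown or untested is made for them only; others in the source may bear on it.

In a functional assay on HL-60 cells (Homo sapiens) for cytotoxicity, read by WST assay, with a stated time of 48 h (a lower number here means that less compound is needed, a higher number that more compound is needed for the effect), compound 2 `O=C1OC[C@H](Cc2ccccc2)[C@H]1Cc1cccc(O)c1` gives > 100000 nM, which is a limit and not a number. Compound 3 `COCOc1cccc(C[C@H]2C(=O)OC[C@@H]2Cc2ccccc2)c1` carries methoxymethyl in place of hydrogen on an oxygen on an aromatic ring, that is, hydroxy becomes methoxymethoxy. Within the data shown here, the one measured step that bears on this is an at least 1.7-fold higher number from compound 1 to compound 2 (0.24 log units; that floor lies within the scatter), so it gives only weak guidance. The expectation rests on compound 1 `Cc1ccccc1C[C@H]1C(=O)OC[C@@H]1Cc1ccccc1` at 57000 nM, which, like compound 3, has no hydroxy. The expected step in this assay is an at least 2.0-fold lower number from compound 2 to compound 3 (0.30 log units; that floor lies within the scatter), towards a lower number. For compound 3 the estimated value is 50000 nM, with an expected range from 15000 nM to 120000 nM.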

Compound 3, half-maximal effective concentration: 80000 nM
Compound 3: middle estimate off by 1.6-fold (0.20 log units), on the low side, within the range that was stated.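

In this assay, hydroxy to methoxymethoxy on this aromatic ring gives an at least 1.2-fold lower number from compound 2 to compound 3 (0.09 log units; that floor lies within the scatter). The methoxymethyl group, with its 3 heavy atoms on the oxygen, therefore still leaves compound 3 with a readable number, which the free hydroxy does not give. For compound 2 the reading is a limit and not a number, so the true size of this step stays unknown: the limit of > 100000 nM in this assay, at which 1 of the 3 values shown sits.

As far as these compounds go, whether the step goes beyond the scatter stays open. Also open, from the compounds shown here alone, is how a smaller methoxy or an amine at this place would read in this assay.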